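The compounds below may be only part of what the source reports. "The series", "measured", "known", "first", "only" and "open" are said of these compounds alone.

Measured compounds:
compound 1 `CC(=O)OC/C(=C\C1CCCCC1)C(=O)c1ccccc1` — in a functional assay on HBL-100 cells (Homo sapiens) for inhibition, read by sulforhodamine B assay, with a stated time of 48 h (a higher number here means a weaker inhibitor of growth, a lower number a stronger inhibitor of growth), compound 1 gives 21000 nM.
compound 2 `CC(=O)OC/C(=C\c1ccc(Cl)cc1)C(=O)c1ccccc1` — in this assay compound 2 gives 2300 nM.

Compound 2 holds the lowest of the two numbers; its nearest neighbour is compound 1, and the step of a 9.1-fold lower number from compound 1 to compound 2 (0.96 log units; beyond the scatter) is the only one measured in the series. Compound 3 `CC(=O)OC/C(=C\c1ccccc1Br)C(=O)c1ccccc1` is not yet measured. It differs from compound 2 by 2-bromophenyl in place of 4-chlorophenyl on a double-bonded chain carbon bound to a double-bonded chain carbon. Among the measured compounds shown here, the one measured step swaps a saturated ring for an aromatic one; compound 3 keeps an aromatic ring, so that step bears on it only insofar as the aryl is retained. For the measured compounds named here, no measured pair speaks to moving a halogen around the ring or to bromine against chlorine. The expected step of a 1.3-fold higher number from compound 2 to compound 3 (0.12 log units; within the scatter) is therefore none beyond the scatter. Compound 3 is estimated at 3000 nM in this assay, with a range from 1000 nM to 9000 nM.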

Compound 3, concentration for 50% growth inhibition: 22000 nM
The estimate for compound 3 lay 7.3-fold (0.87 log units) below the measured number; the whole stated range lies below it.
By their numbers in this assay, from the lowest: compound 2; then compounds 1 and 3 (each within the scatter of the next).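

In this assay, the substituent on the ring at the double-bonded chain carbon matters: with the aromatic ring kept, the change gives a 9.6-fold higher number from compound 2 to compound 3 (0.98 log units; beyond the scatter), so an aromatic ring alone does not carry the advantage of compound 2 over compound 1. The cyclohexyl and 2-bromophenyl groups are not separated here, with a 1.0-fold higher number from compound 1 to compound 3 (0.02 log units; within the scatter), and among these compounds the advantage belongs to 4-chlorophenyl alone rather than to aryl groups in general. Nothing available accounts for this difference.

This change alters both the halogen and its place on the ring, and the three compounds cannot separate the two; 2-chlorophenyl and 4-bromophenyl would do so. From the compounds shown here alone, how plain phenyl or a ring bearing an amine would compare also remains open.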